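Methylating the second phenol in a piperazine aryl series

A few compounds are considered here, and "the series" means these few. Any claim that something is new, unique, unknown or untested is made for them only; others in the source may bear on it.

Compound 1: `COc1ccccc1N1CCN(CCCNc2ncccc2C(=O)N(C)C)CC1` gives 20 nM in a functional assay on aorta for antagonist activity at Alpha-1D adrenergic receptor (Rattus norvegicus); a lower number here means tighter binding, a higher number weaker binding.
Compound 2: `CN(C)C(=O)c1cccnc1NCCCN1CCN(c2ccccc2O)CC1` gives 63.1 nM in this assay.
Compound 3: `COc1cc(O)ccc1N1CCN(CCCNc2ncccc2C(=O)N(C)C)CC1` gives 79.4 nM in this assay.

The three measured compounds share one core and differ only in the aryl group carried by the ring nitrogen. Between compound 2 and compound 1 the change is methyl in place of hydrogen on an oxygen on an aromatic ring; the step it made is a 3.2-fold lower number from compound 2 to compound 1 (0.50 log units; beyond the scatter). Compound 3 carries a further hydroxy group, and the difference from compound 2 is 4-hydroxy-2-methoxyphenyl in place of 2-hydroxyphenyl on an amine nitrogen in a ring; in this assay the two are within the scatter of each other, a 1.3-fold higher number from compound 2 to compound 3 (0.10 log units; within the scatter). Compared with compound 1, compound 3 sits at the high end: a 4.0-fold higher number from compound 1 to compound 3 (0.60 log units; beyond the scatter).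

Compound 4 is `COc1ccc(N2CCN(CCCNc3ncccc3C(=O)N(C)C)CC2)c(OC)c1`, not yet measured. Among the compounds with values here, its difference from compound 3 is methyl in place of hydrogen on an oxygen on an aromatic ring, and its place description matches word for word the one in the step from compound 2 to compound 1; only the wider view differs, where it reads hydroxy to methoxy on a 4-hydroxy-2-methoxyphenyl rather than on a 2-hydroxyphenyl. Because a 3.2-fold lower number from compound 2 to compound 1 (0.50 log units; beyond the scatter) was observed for this same change, a step of similar direction is expected for compound 4, estimated as a 2.5-fold lower number from compound 3 to compound 4 (0.39 log units; beyond the scatter). Within the data shown here, the estimate for compound 4 in this assay is therefore 32 nM, expected to fall between 12 nM and 90 nM, with the width reflecting that only one earlier instance of this change is available and that the oxygen it touches sits in a different surrounding on the ring.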

Compound 4, dissociation constant: 1000 nM
Compound 4: the middle estimate sits 31-fold (1.49 log units) below what was measured; the whole stated range lies below it.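

Methyl in place of hydrogen on an oxygen on an aromatic ring does not carry over as a fixed step in this assay. On the core with the 4-hydroxy-2-methoxyphenyl group, it gives a 13-fold higher number from compound 3 to compound 4 (1.10 log units; beyond the scatter), and the two instances of the change disagree even in direction: the same change on two cores in this assay, a 3.2-fold lower number (0.50 log units; beyond the scatter) from compound 2 to compound 1 and a 13-fold higher number (1.10 log units; beyond the scatter) from compound 3 to compound 4, 40-fold (1.60 log units) apart, beyond the scatter of two such steps
The result also leaves 2,4-dimethoxyphenyl well apart from the other two aryl groups, with a 16-fold higher number from compound 2 to compound 4 (1.20 log units; beyond the scatter) and a 50-fold higher number from compound 1 to compound 4 (1.70 log units; beyond the scatter). These two instances show that the effect of this methylation depends on what else the aryl group carries, but they do not show why, and two cases cannot give a rule for other aryl groups in the series.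

Going by these compounds, it remains open whether the high number of compound 4 is tied to methoxy specifically at that aromatic carbon, since hydroxy there gave only a 4.0-fold higher number from compound 1 to compound 3 (0.60 log units; beyond the scatter), or whether a fluorine, an ethoxy or an amine in the same place would fall closer to one or the other. Also open, on these data alone, is whether the same contrast between the two methylations would hold with a longer chain in the shared core.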